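The source may report more compounds than this note shows. Statements on the series, on what has been measured and on what is new or still open speak of the compounds shown alone.

Compound 1 `CC1=CC[C@H]2[C@H](CC[C@]2(C)O)C(C)(C)[C@@H]1CC[C@H]1[C@]2(C)CC[C@H](OC(=O)c3ccncc3)C(C)(C)O[C@H]2CC[C@@]1(C)O` gives 25300 nM in a functional assay on MCF7 cells (Homo sapiens) for antiproliferative activity, read by MTT assay, with a stated time of 72 h; on this read-out higher numbers stand for weaker inhibition and lower numbers for stronger inhibition.
Compound 2 `CC1=CC[C@H]2[C@@H]1CC=C(C)[C@@H](CC[C@H]1[C@]3(C)CC[C@H](OC(=O)c4ccncc4)C(C)(C)O[C@H]3CC[C@@]1(C)O)C2(C)C` gives only a limit, > 50000 nM, in this assay.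

Within the data shown here, compound 1 therefore holds the only number recorded in this assay; the other value is a limit (the limit of > 50000 nM in this assay, at which 1 of the 2 values shown sits). Compound 3 `CC1=CC[C@H]2[C@H](CC[C@]2(C)O)C(C)(C)[C@@H]1CC[C@H]1[C@]2(C)CC[C@H](OC(=O)c3cccc(C(F)(F)F)c3)C(C)(C)O[C@H]2CC[C@@]1(C)O` differs from compound 1 by 3-(trifluoromethyl)phenyl in place of pyridin-4-yl on a carbonyl carbon. Among the measured compounds shown here, no measured pair shows this change, so its size is not known from the data. Compound 3 is expected to stay within the usual scatter of compound 1, a step of a 1.4-fold lower number from compound 1 to compound 3 (0.15 log units; within the scatter). In this assay compound 3 is estimated at 18000 nM, with a range from 5000 nM to 50000 nM.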

Compound 3, half-maximal inhibitory concentration: 37900 nM
Estimate against measurement, compound 3: 2.1-fold (0.32 log units) below; the range from low to high includes it.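

Compound 3 puts a number on this position in this assay: 3-(trifluoromethyl)phenyl in place of pyridin-4-yl on a carbonyl carbon gives a 1.5-fold higher number from compound 1 to compound 3 (0.18 log units; within the scatter) in this pair. The hetero atom of pyridin-4-yl is therefore not needed to keep the number at this level. Nothing measured here gives a reason for this step.

The compounds shown leave open whether an amine or a carboxylic acid on this ring, or a longer chain in its place, would move the number beyond the scatter. They also leave open how this change would read on the core of compound 2.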